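This account rests on a few compounds, and the source may have more. Where it says the series, first, only, none or still open, it means among the compounds named here.

Compound 1 `O=c1[nH]c2ccc(-c3cn[nH]c3)cc2cc1-c1cc2cc(CN3CCC(F)CC3)ccc2[nH]1`: 2.5 h
Compound 2 `CC(=O)N1CCN(Cc2ccc3[nH]c(-c4cc5cc(-c6cn[nH]c6)ccc5[nH]c4=O)cc3c2)CC1`: 1.5 h

Both values come from an in vivo ADME assay on the whole organism for metabolic stability, with Canis familiaris (Canis lupus familiaris) as the target, at a dose of 0.25 mg/kg by the intravenous route; on this read-out lower numbers stand for a shorter-lived compound and higher numbers for a longer-lived compound. Compound 2 has one measured neighbour, compound 1, and the two lie within the scatter of each other, so compound 2 holds no distinct place in this pair. Compound 3 `COCC(=O)N1CCN(Cc2ccc3[nH]c(-c4cc5cc(-c6cn[nH]c6)ccc5[nH]c4=O)cc3c2)CC1` differs from compound 2 in one place: methoxy in place of hydrogen on a saturated chain carbon bound to a carbonyl carbon. This is methoxy in place of hydrogen on a saturated chain carbon bound to a carbonyl carbon, which turns 4-acetylpiperazin-1-yl into 4-((methoxymethyl)carbonyl)piperazin-1-yl. For the measured compounds named here, no measured compound carries this methoxy, so the data hold no direct reading of it. Going by the values given here, the one measured step that bears on it is a 1.7-fold lower number from compound 1 to compound 2 (0.22 log units; within the scatter), with 4-acetylpiperazin-1-yl in place of 4-fluoropiperidin-1-yl. That exchange of a whole group stayed within the scatter, so a step beyond the scatter is not expected here in this assay. The expected step, a slight one at most, is a 1.1-fold lower number from compound 2 to compound 3 (0.03 log units; within the scatter). Compound 3 is estimated at 1.4 h, with an expected range from 0.7 h to 2.8 h.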

Compound 3, half-life: 2 h
Compound 3: the middle estimate sits 1.4-fold (0.15 log units) below what was measured; low and high end bracket the measured number.
By their numbers in this assay, from the lowest: compounds 2, 3 and 1 (each within the scatter of the next).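

In this assay, for the compounds shown here, the first direct reading of this position is a 1.3-fold higher number from compound 2 to compound 3 (0.12 log units; within the scatter), so methoxy in place of hydrogen on the saturated chain carbon bound to the carbonyl carbon, which turns acetyl into (methoxymethyl)carbonyl, leaves the half-life within the scatter. The larger exchange of the whole group stays within it as well, at a 1.3-fold lower number from compound 1 to compound 3 (0.10 log units; within the scatter), so 4-fluoropiperidin-1-yl, 4-acetylpiperazin-1-yl and 4-((methoxymethyl)carbonyl)piperazin-1-yl cannot be told apart on this read-out in these three compounds. Nothing at hand accounts for how closely these three half-lives fall together.

From the compounds shown here alone, what an amine, a carboxylic acid or a longer chain on the same saturated chain carbon would do in this assay stays open. Also open is whether any change at this position can produce a step beyond the scatter, as the three compounds shown establish only that methoxy and the two group exchanges do not.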